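Benzylpiperidine amide series: bromo in place of methoxy

The source may report more compounds than this note shows. Statements on the series, on what has been measured and on what is new or still open speak of the compounds shown alone.

Compound 1 `O=C(NC1CCN(Cc2ccccc2)CC1)c1cc(=O)c2ccccc2o1` carries the amide directly on the piperidine ring; in an assay on isolated protein for inhibition of Amine oxidase [flavin-containing] A (Homo sapiens), read by fluorescence and Amplex Red, with stated times of 15 min and 20 min, tested at 100 uM (a lower number here means less inhibition, a higher number more inhibition at the concentration tested (going by the name of the read-out)), compound 1 gives 29.7%. Compound 2 `COc1ccc2occ(C(=O)NCCC3CCN(Cc4ccccc4)CC3)c(=O)c2c1` has a chain between the amide and the piperidine and a methoxy on its core; in this assay compound 2 gives 72.4%, the higher of the two numbers recorded, and its distance from compound 1 lies beyond the scatter. Among the measured compounds shown here, compound 1 and compound 2 differ in more than one place, so the pair shows only that the two values sit far apart.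

Compound 3 `O=C(NCCC1CCN(Cc2ccccc2)CC1)c1coc2ccc(Br)cc2c1=O` keeps the chain and the benzylpiperidine of compound 2 and differs in one place: bromo in place of methoxy on an aromatic carbon.

For the measured compounds named here, no measured pair covers this exchange, so nothing fixes its size. The expectation for compound 3 is a step in this assay of a number 7.4 percentage points lower from compound 2 to compound 3 (within the scatter), a change of at most moderate size, with either direction possible and none beyond the scatter the most probable outcome. The estimate for compound 3 in this assay is 65%, with a range from 40% to 85%.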

Compound 3, a percentage reported as inhibition, at one concentration (the size of the read-out at that concentration, not a potency): 48.2%
For compound 3 the middle estimate is 16.8 percentage points above the measured one; low and high end bracket the measured number.
By their numbers in this assay, from the lowest: compound 1; then compound 3; then compound 2.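

Placing bromo in place of methoxy on an aromatic carbon of the six-membered aromatic ring of carbon only, with the chain and the benzylpiperidine held constant, gives in this assay a number 24.2 percentage points lower from compound 2 to compound 3 (beyond the scatter), the only single-place step in the series so far. This shows that the group at this position matters to the read-out in this assay, and that for this pair methoxy gives the higher number; the gap between compound 1 and compound 2 could not be tied to any one place, whereas this step can. Methoxy brings a hydrogen-bond acceptor and bromo none, but no measurement at hand bears on what lies behind the step.

From the compounds shown here alone, with only these two groups at this position, it remains open whether the numbers follow the acceptor, so a hydroxy, an ethoxy, a chloro or an amine there would be the informative comparisons. Also open, going by these compounds, is whether the same exchange gives a step of similar size when the amide sits directly on the piperidine ring, as in compound 1.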